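The source may report more compounds than this note shows. Statements on the series, on what has been measured and on what is new or still open speak of the compounds shown alone.

Measured in a functional assay on BGC-823 cells (Homo sapiens) for cytotoxicity, read by MTT assay, with a stated time of 48 h; a higher number here means a weaker inhibitor, a lower number a stronger inhibitor:
compound 1 `O=C(CSc1nnc(-c2ccncc2)o1)N/N=C/c1cccc(F)c1` gives 27500 nM
compound 2 `COc1cccc(/C=N/NC(=O)CSc2nnc(-c3ccncc3)o2)c1` gives 15800 nM
compound 3 `O=C(CSc1nnc(-c2ccncc2)o1)N/N=C/c1cc(Cl)ccc1O` gives 5470 nM

Compound 3 holds the lowest number of the three; the two steps that reach it read a 2.9-fold lower number from compound 2 to compound 3 (0.46 log units; beyond the scatter) and a 5.0-fold lower number from compound 1 to compound 3 (0.70 log units; beyond the scatter), both beyond the scatter, so within this small set compound 3 is the strongest inhibitor in this assay. The shift between compound 1 and compound 2 is a 1.7-fold lower number from compound 1 to compound 2 (0.24 log units; within the scatter), within the scatter.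

Compound 4 `O=C(CSc1nnc(-c2ccncc2)o1)N/N=C/c1cc(Br)ccc1O` differs from compound 3 by bromo in place of chloro on an aromatic carbon. Within the data shown here, none of the measured steps bears directly on it: the two steps that reach compound 3 exchange the whole aryl group, not one halogen for another, and no pair among the measured compounds varies only a halogen. What is known is that the 5-chloro-2-hydroxyphenyl pattern sits at the low end, and compound 4 keeps it. Among the measured compounds shown here, with no halogen-swap precedent, no step beyond the scatter is expected; the step is estimated as a 1.1-fold lower number from compound 3 to compound 4 (0.06 log units; within the scatter). Compound 4 is accordingly expected to give about 4800 nM in this assay, within 2000 nM to 12000 nM.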

Compound 4, half-maximal inhibitory concentration: 9590 nM
Beside the measured number, compound 4's estimate is 2.0-fold (0.30 log units) below it; the measured number falls inside the stated range.
By their numbers in this assay, from the lowest: compounds 3, 4, 2 and 1 (each within the scatter of the next, the first and the last beyond it).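

In this assay, among these compounds, the only halogen exchange (a 1.8-fold higher number from compound 3 to compound 4 (0.24 log units; within the scatter)) leaves chloro and bromo unseparated at this position, para to a hydroxy group. The 5-bromo-2-hydroxyphenyl group stays clear of the 3-fluorophenyl group (a 2.9-fold lower number from compound 1 to compound 4 (0.46 log units; beyond the scatter)) but not of the 3-methoxyphenyl group (a 1.6-fold lower number from compound 2 to compound 4 (0.22 log units; within the scatter)), so the separation from compound 2 seen with compound 3 does not carry over to compound 4. No evidence is available that bears on these readings.

Going by these compounds, whether a methyl, an amine or a carboxylic acid in place of the halogen would read differently remains open, and so does the outcome with a hydrogen there. The part played by the hydroxy group also remains open, as no pair shown varies it alone.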